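Phenyl in Place of Methyl on the Amide Nitrogen

A few compounds are considered here, and "the series" means these few. Any claim that something is new, unique, unknown or untested is made for them only; others in the source may bear on it.

Of the compounds shown here, two with a shared core have been measured in an in vitro assay on Sf9 cells for inhibition of 17-beta-hydroxysteroid dehydrogenase type 1 (Homo sapiens), tested at 1 uM; on this read-out lower numbers stand for a weaker effect and higher numbers for a stronger effect at the one concentration tested. Compound 1 `O=C(c1c(O)ccc2cc(-c3cccc(O)c3)ccc12)N1CCOCC1` gives 62%, and compound 2 `CNC(=O)/C=C/c1c(O)ccc2cc(-c3cccc(O)c3)ccc12` gives 58%. Among the measured compounds shown here, the single measured step, a number 4 percentage points lower from compound 1 to compound 2 (within the scatter), exchanged the whole side chain on the aromatic carbon and stayed within the scatter. Compound 2 thus sits beside compound 1, the two numbers within the scatter of each other.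

Compound 3 `O=C(/C=C/c1c(O)ccc2cc(-c3cccc(O)c3)ccc12)Nc1ccccc1` is the next compound. It differs from compound 2 as follows: phenyl in place of methyl on an amide-type nitrogen. For the measured compounds named here, the only measured step changed a different part of the molecule, so no step bears directly on this exchange; what the data do show is that a change of the side chain left the read-out within the scatter. Without a step on the amide nitrogen, a step of no size beyond the scatter is the expectation, written as a number 3 percentage points lower from compound 2 to compound 3 (within the scatter). Compound 3 is therefore estimated to give 55%, with a range from 35% to 75%.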

Compound 3, a percentage reported as inhibition, at one concentration (the size of the read-out at that concentration, not a potency): 60%
For compound 3 the middle estimate is 5 percentage points below the measured one; low and high end bracket the measured number.
By their numbers in this assay, from the lowest: compounds 2, 3 and 1 (each within the scatter of the next).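

In this assay, phenyl in place of methyl on the amide-type nitrogen gives a number 2 percentage points higher from compound 2 to compound 3 (within the scatter), the first step read at this nitrogen. A much larger group, one six-membered aromatic ring of carbon only instead of a single carbon, therefore leaves the read-out at the one concentration tested within the scatter, so compound 2 and compound 3 cannot be told apart here. No further measurement is available to explain this result.

Still open, from the compounds shown here alone, is what a benzyl group, a pyridine ring or a phenyl ring carrying a carboxylic acid or an amine would do on this nitrogen. Also open, going by these compounds, is whether compound 2 and compound 3 would remain this close at other concentrations.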